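A tert-butylphenyl sulfonamide from a fluorophenyl starting point

The source may hold more compounds than are shown below. What is called first, only, known or untested is meant among the compounds shown, and "the series" means these compounds.

Compound 1, `O=C(c1ccc(OCCCN2CC[C@H](NS(=O)(=O)c3ccccc3F)C2)cc1)C1CC1`, was measured in an assay on isolated protein for binding affinity to histamine H2 receptor (Homo sapiens) (a lower number here means a stronger inhibitor, a higher number a weaker inhibitor), and gives 1550 nM. Going by the values given here, of the two numbers so far, compound 1 has the lower one, but its companion compound 2, `CC(=O)c1ccc(OCCCN2CC[C@H](NS(=O)(=O)c3ccc(C#N)cc3)C2)cc1`, gives 2300 nM in this assay, and the two values lie within the scatter of each other, so nothing separates them. Compound 2 differs from compound 1 in more than one place, so its value says nothing on its own about any single change.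

The step to the unmeasured compound 3, `CC(C)(C)c1ccc(S(=O)(=O)N[C@H]2CCN(CCCOc3ccc(C(=O)C4CC4)cc3)C2)cc1`, changes one place: 4-(tert-butyl)phenyl in place of 2-fluorophenyl on a sulfonyl sulfur. Among the compounds with values here, no measured pair in this set isolates this change, so there is no step to lean on. He therefore expects the step from compound 1 to compound 3 to be small, a 1.0-fold lower number from compound 1 to compound 3 (0.01 log units; within the scatter), in no clear direction and not beyond the scatter. Within the data shown here, for compound 3 he estimates 1500 nM in this assay, with a range from 400 nM to 6000 nM, wide because the only anchor is the single value of compound 1, 1550 nM.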

Compound 3, inhibition constant: 730 nM
Beside the measured number, compound 3's estimate is 2.1-fold (0.31 log units) above it; the measured number falls inside the stated range.
By their numbers in this assay, from the lowest: compound 3; then compounds 1 and 2 (each within the scatter of the next).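

In this assay, going by these compounds alone, the group on the sulfonyl sulfur turns out to be a place where the number can move, and the change gives a 2.1-fold lower number from compound 1 to compound 3 (0.33 log units; beyond the scatter) as the first step in the set that isolates a single place. The step is modest but beyond the scatter, and it shows that this position accepts 4-(tert-butyl)phenyl, with 10 heavy atoms, in place of 2-fluorophenyl, with 7, without any loss of binding; the number in fact goes lower. Nothing in the data offers an explanation for this step, which therefore stands as an observation only.

The swap removes the fluorine and brings in the tert-butyl group in one move, and this single step cannot show which of the two accounts for the lower number. Still open, as far as these compounds go, is how the number would respond to a plain phenyl on the sulfonyl sulfur, or to an amine or a carboxylic acid in place of the tert-butyl group, and whether the step would hold on a core other than that of compound 1.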